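A few compounds are considered here, and "the series" means these few. Any claim that something is new, unique, unknown or untested is made for them only; others in the source may bear on it.

Compound 1 `COc1ccc(S(=O)(=O)Nc2cccc([N+](=O)[O-])c2)cc1` and compound 2 `Cc1ccc(S(=O)(=O)Nc2cccc([N+](=O)[O-])c2)cc1` share a core and differ in one place: methyl in place of methoxy on an aromatic carbon. In a physicochemical assay for acid dissociation, compound 1 gives 8.44, and compound 2 gives 8.27; the step is a number 0.17 log units lower from compound 1 to compound 2 (within the scatter). Compound 3 `COc1ccc(S(=O)(=O)Nc2ccc(F)cc2)cc1` carries a different core; the difference between the two cores is not broken down here. In this assay compound 3 gives 9.32, the highest of the three numbers, and its two values stand well apart from those of compound 1 and compound 2.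

Compound 4 `Cc1ccc(S(=O)(=O)Nc2ccc(F)cc2)cc1` has not yet been measured. It differs from compound 3 by the same change that leads from compound 1 to compound 2: methyl in place of methoxy on an aromatic carbon. Because that change gave a number 0.17 log units lower from compound 1 to compound 2 (within the scatter), a step of about the same size is expected in this assay for compound 4, namely a number 0.17 log units lower from compound 3 to compound 4 (within the scatter). For compound 4 the expected value in this assay is therefore 9.15. The estimated range for compound 4 runs from 8.85 to 9.45.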

Compound 4, acid dissociation constant: 9.2
Beside the measured number, compound 4's estimate is 0.05 log units below it; the range from low to high includes it.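

In this assay, methyl in place of methoxy gives a number 0.12 log units lower from compound 3 to compound 4 (within the scatter), which sits with the earlier a number 0.17 log units lower from compound 1 to compound 2 (within the scatter), so on both cores shown this change leaves the read-out within the scatter and the earlier result carries over to the second core. Going by these compounds alone, this shows only that a change with no step beyond the scatter on the core of compound 1 also has none on the core of compound 3; it does not show that steps of larger size would carry from one core to the other, and two pairs make no rule for the wider series. Nothing shown here gives a reason for this result.

The compounds shown leave open what happens when methoxy gives way to a quite different group on that aromatic carbon, such as trifluoromethyl, an amine or a carboxylic acid. They also leave open whether any step beyond the scatter from such a group would keep its size on both cores.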